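Fluorophenylsulfonyl series: notes towards one pending estimate

This account rests on a few compounds, and the source may have more. Where it says the series, first, only, none or still open, it means among the compounds named here.

Three compounds of this series have been measured in an in vitro assay on HEK ts201 cells for negative allosteric modulation of Neuronal acetylcholine receptor; alpha4/beta2 (Homo sapiens), read by fluorescence and calcium flux, with a stated time of 1.5 s; on this read-out lower numbers stand for stronger inhibition and higher numbers for weaker inhibition:

compound 1, `COc1ccc(NC(=O)CN2CCN(S(=O)(=O)c3ccc(F)cc3)CC2)cc1`, gives 21100 nM
compound 2, `COc1ccc(NC(=O)CN2CCN(S(=O)(=O)c3ccccc3F)CC2)cc1`, gives 17100 nM
compound 3, `O=C(CN1CCN(S(=O)(=O)c2ccc(F)cc2)CC1)Oc1ccccc1-c1ccccc1`, gives 12200 nM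

Compound 1 and compound 2 share one core and differ in a single place: 2-fluorophenyl in place of 4-fluorophenyl on a sulfonyl sulfur. In this assay the step is a 1.2-fold lower number from compound 1 to compound 2 (0.09 log units; within the scatter), so the two values are not distinguished by the measurement. Compound 3 carries a different core; how the core of compound 3 differs from the core of compound 1 is not broken down here. Compound 3 has the lowest of the three numbers, but its distances to compound 2 and to compound 1 are both within the scatter, so no order among the three is claimed.

Compound 4, `O=C(CN1CCN(S(=O)(=O)c2ccccc2F)CC1)Oc1ccccc1-c1ccccc1`, is not yet measured. It differs from compound 3 by 2-fluorophenyl in place of 4-fluorophenyl on a sulfonyl sulfur. Among the compounds with values here, the place around the change is described in the same words for both pairs, so this is the same change as the one from compound 1 to compound 2. Within the data shown here, the only guide to its size is that earlier pair, where the step was flat, and the two cores are only represented by one pair each, so no pattern beyond these compounds is asserted.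

On that basis compound 4 is expected to sit close to compound 3, with an estimated step of a 1.2-fold lower number from compound 3 to compound 4 (0.07 log units; within the scatter), resting on the flat step a 1.2-fold lower number from compound 1 to compound 2 (0.09 log units; within the scatter). For compound 4 the estimate in this assay is 10500 nM, expected to lie between 5000 nM and 22000 nM.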

Compound 4, half-maximal inhibitory concentration: 20900 nM
Compound 4: middle estimate off by 2.0-fold (0.30 log units), on the low side, and the stated range covers the measured number.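

In this assay, moving from 4-fluorophenyl to 2-fluorophenyl on a sulfonyl sulfur gives a 1.7-fold higher number from compound 3 to compound 4 (0.23 log units; within the scatter), so on the core of compound 3 the measurement does not separate the two fluorophenyl groups. The same change on the core of compound 1 was also unresolved, and the two steps do not differ from each other by more than repeated measurement allows: the same change on two cores in this assay, a 1.2-fold lower number (0.09 log units; within the scatter) from compound 1 to compound 2 and a 1.7-fold higher number (0.23 log units; within the scatter) from compound 3 to compound 4, 2.1-fold (0.33 log units) apart, within the scatter of two such steps. This shows that the change has no resolved effect on either core and that no dependence on the core can be read from these pairs, but with one pair per core it does not show that the step is truly the same on both, and the different signs of the two steps are not to be taken as a reversal.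

Every compound shown carries a fluorophenyl group on the sulfonyl sulfur, so it remains open how a plain phenyl, an aminophenyl, a carboxyphenyl or a longer alkyl chain at that place would read in this assay. As far as these compounds go, it also remains open whether the exchange of 4-fluorophenyl for 2-fluorophenyl stays unresolved on any core beyond those of compound 1 and compound 3.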